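Amide to urea: what compound 4 is expected to give

This account rests on a few compounds, and the source may have more. Where it says the series, first, only, none or still open, it means among the compounds named here.

Compound 2 `COc1cc(-c2nn(-c3cccc(NC(=O)c4cccc(C(F)(F)F)c4)c3)cc2-c2ccncc2)ccc1Cl` carries an amide and gives 1620 nM in a functional assay on U-251 cells (Homo sapiens) for inhibition, read by sulforhodamine B assay, with a stated time of 48 h (on this read-out lower numbers stand for stronger inhibition of growth and higher numbers for weaker inhibition of growth), the highest of the three numbers measured. Its urea relatives sit lower: compound 1 `COc1cc(-c2nn(-c3cccc(NC(=O)Nc4cc(C(F)(F)F)cc(C(F)(F)F)c4)c3)cc2-c2ccncc2)ccc1Cl` gives 590 nM and compound 3 `O=C(Nc1cccc(-n2cc(-c3ccncc3)c(-c3ccc(Cl)c(O)c3)n2)c1)Nc1cc(C(F)(F)F)cc(C(F)(F)F)c1` gives 463 nM, and the one-place step a 1.3-fold lower number from compound 1 to compound 3 (0.11 log units; within the scatter) shows that the hydrogen for methyl exchange changes little. Compound 4 `COc1cc(-c2nn(-c3cccc(NC(=O)Nc4ccc(Cl)c(C(F)(F)F)c4)c3)cc2-c2ccncc2)ccc1Cl` arises from compound 2 by the change ((4-chloro-3-(trifluoromethyl)phenyl)amino in place of 3-(trifluoromethyl)phenyl on a carbonyl carbon). For the measured compounds named here, no measured single step covers this amide to urea exchange, but the values of compound 2 and compound 1 suggest the urea form is the stronger one, so compound 4 is expected to show a step of a 2.7-fold lower number from compound 2 to compound 4 (0.43 log units; beyond the scatter) in this assay. Compound 4 is therefore estimated at 600 nM, within a range from 300 nM to 1400 nM.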

Compound 4, concentration for 50% growth inhibition: 985 nM
Beside the measured number, compound 4's estimate is 1.6-fold (0.22 log units) below it; the measured number falls inside the stated range.
By their numbers in this assay, from the lowest: compounds 3, 1, 4 and 2 (each within the scatter of the next, the first and the last beyond it).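

In this assay, for the compounds shown here, replacing 3-(trifluoromethyl)phenyl with (4-chloro-3-(trifluoromethyl)phenyl)amino on the carbonyl carbon gives a 1.6-fold lower number from compound 2 to compound 4 (0.22 log units; within the scatter) and so provides the first direct comparison at this position. This amide-to-urea exchange, with its added chlorine, does not clearly separate the two compounds. No measurement here accounts for the size of this step.

As far as these compounds go, because the amino link and the chlorine enter together, their separate contributions remain unknown. From the compounds shown here alone, it also remains open how a piperidine on this carbonyl carbon would behave in this assay.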